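Removing the Amide Methyl from Compound 1

The source may hold more compounds than are shown below. What is called first, only, known or untested is meant among the compounds shown, and "the series" means these compounds.

Measured so far:
compound 1, `COc1cc(N(C)C(=O)c2ccc(F)cc2)cc(OC)c1OC`: in a functional assay on Daoy cells (Homo sapiens) for cytotoxicity, read by MTT assay, with a stated time of 72 h (a lower number here means a stronger inhibitor, a higher number a weaker inhibitor), compound 1 gives >= 125000 nM, which is a limit of the assay rather than a number.
compound 2, `COc1ccc(C(=O)N(C)c2cc(OC)c(OC)c(OC)c2)cc1`: in this assay compound 2 gives >= 125000 nM, again a limit of the assay.

Compound 1 therefore stands at the edge of what the assay can report: the limit of >= 125000 nM in this assay, at which 2 of the 2 values shown sit. Among the compounds with values here, the only measured step, a step that the two limits leave unreadable from compound 1 to compound 2, cannot be read, so no measured step gives a usable size for the change studied here.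

Compound 3, `COc1cc(NC(=O)c2ccc(F)cc2)cc(OC)c1OC`, differs from compound 1 by hydrogen in place of methyl on an amide-type nitrogen. With no readable step to draw on, the expectation for compound 3 rests on the two limits alone. Compound 3 is expected to give 125000 nM, with a range from 60000 nM to 250000 nM, in this assay, most likely reported once more as a limit. The expected step, a number no higher from compound 1 to compound 3 (the limit leaves the size open), is accordingly none beyond the scatter.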

Compound 3, half-maximal inhibitory concentration: >= 125000 nM
Compound 3: no number, only a limit; the forecaster's own chance of this, stated with the estimate: 85%; the middle value lies on the limit itself.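

No step can be read from compound 1 to compound 3, as both values are limits of the assay rather than numbers: the limit of >= 125000 nM in this assay, at which 3 of the 3 values shown sit. The compounds shown leave open whether hydrogen in place of methyl on the amide-type nitrogen changes cytotoxicity at all.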